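Ester tail variation on the shared core: removing the decyloxy chain

This account rests on a few compounds, and the source may have more. Where it says the series, first, only, none or still open, it means among the compounds named here.

Measured compounds:
compound 1 `CO[C@@H](C(=O)NC1CC[C@@H](OC(=O)CCc2cccnc2)CNC1=O)[C@H](O)[C@@H](O)[C@H](O)/C=C/C(C)(C)C` gives 460 nM in an in vivo functional assay on the whole organism (MDA-MB-435 cells, Homo sapiens) for antiproliferative activity; on this read-out higher numbers stand for weaker inhibition and lower numbers for stronger inhibition;
compound 2 `CCCCCc1ccc(C(=O)O[C@@H]2CCC(NC(=O)[C@H](OC)[C@H](O)[C@@H](O)[C@H](O)/C=C/C(C)(C)C)C(=O)NC2)cc1` gives 20 nM in this assay;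
compound 3 `CCCCCCCCCCOc1ccc(C(=O)O[C@@H]2CCC(NC(=O)[C@H](OC)[C@H](O)[C@@H](O)[C@H](O)/C=C/C(C)(C)C)C(=O)NC2)cc1` gives 10 nM in this assay.

Compound 3 shows the lowest of the three numbers in this assay. Its nearest neighbour is compound 2, with a 2.0-fold lower number from compound 2 to compound 3 (0.30 log units; within the scatter), so these two cannot be ordered. Compound 1 is far away: a 23-fold lower number from compound 1 to compound 2 (1.36 log units; beyond the scatter) carries the whole spread of the set.

Compound 4 `CO[C@@H](C(=O)NC1CC[C@@H](OC(=O)c2ccccc2)CNC1=O)[C@H](O)[C@@H](O)[C@H](O)/C=C/C(C)(C)C` is the next step from compound 3: hydrogen in place of decyloxy on an aromatic carbon. The aromatic ester is kept, but the chain on the ring is gone. For the measured compounds named here, two measured steps bear on this. The change from pentyl to decyloxy gave a 2.0-fold lower number from compound 2 to compound 3 (0.30 log units; within the scatter), so chain length alone moved little. The exchange of the whole ester group gave a 23-fold lower number from compound 1 to compound 2 (1.36 log units; beyond the scatter), so the ester part as a whole matters greatly. Compound 4 keeps the aromatic ester of compound 2 and compound 3 without any chain, so a moderate rise in number is expected, short of the position of compound 1.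

For compound 4 the expected step is a 10-fold higher number from compound 3 to compound 4 (1.00 log units; beyond the scatter), with an estimate of 100 nM in this assay, range 30 nM to 400 nM.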

Compound 4, half-maximal inhibitory concentration: 370 nM
For compound 4 the middle estimate is 3.7-fold (0.57 log units) below the measured one; measured number inside the range.
By their numbers in this assay, from the lowest: compounds 3 and 2 (each within the scatter of the next); then compounds 4 and 1 (each within the scatter of the next).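

In this assay the aromatic ester alone does not hold the low numbers: hydrogen in place of decyloxy gives a 37-fold higher number from compound 3 to compound 4 (1.57 log units; beyond the scatter) and hydrogen in place of pentyl gives a 19-fold higher number from compound 2 to compound 4 (1.27 log units; beyond the scatter) so the chain on the aromatic carbon is what separates compound 2 and compound 3 from compound 4. Phenyl in place of 2-(pyridin-3-yl)ethyl gives a 1.2-fold lower number from compound 1 to compound 4 (0.09 log units; within the scatter) so the bare benzoate ester of compound 4 cannot be told apart from the ester of compound 1. The large gain on going to compound 2 therefore follows the pentyl-bearing ring as a whole, not the aromatic ester by itself.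

On these data alone, whether a methyl or ethyl group, an amine or a carboxylic acid on this carbon would keep the low numbers stays open. Nothing shown gives a reason for these steps.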